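The compounds below may be only part of what the source reports. "The series", "measured", "known", "first", "only" and "open" are said of these compounds alone.

Working notes on the series

Two compounds of the shared core have been run in a functional assay on the whole organism for inhibition, with Rattus norvegicus as the target, at a dose of 30 mg/kg by the oral route; on this read-out lower numbers stand for less inhibition and higher numbers for more inhibition at the one dose given (going by the name of the read-out). Compound 1, `O=C(NCCCOc1ccc2nc(O)ccc2c1)N(C1CCCCCC1)[C@H]1CCCC[C@@H]1O`, gives 11%. Compound 2, `CCN(CCCOc1ccc2nc(O)ccc2c1)C(=O)N(C)C1CCCCC1`, gives 12%. Compound 1 sits at the bottom of the two numbers, but its gap to compound 2 lies within the usual scatter of this read-out, so the two compounds cannot be told apart on this assay; both sit at a low level of inhibition at the single oral dose.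

The next compound, compound 3, `O=C(NCCCOc1ccc2nc(O)ccc2c1)N(C1CC1)[C@H]1CCCC[C@@H]1O`, is not yet measured. Relative to compound 1 the change is cyclopropyl in place of cycloheptyl on an amide-type nitrogen. Within the data shown here, no step between measured compounds is available, so there is no measured guide to the size of change this assay shows for such a swap.

With compound 1 at 11% and compound 2 at 12% both low, the expected step is none beyond the scatter, a number 1 percentage points higher from compound 1 to compound 3 (within the scatter). Compound 3 is estimated at 12% in this assay, within a range from 0% to 35%.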

Compound 3, a percentage reported as inhibition, in the whole organism at one dose (the size of the read-out at that dose, not a potency): 13%
Compound 3: middle estimate off by 1 percentage points, on the low side; the range from low to high includes it.
By their numbers in this assay, from the lowest: compounds 1, 2 and 3 (each within the scatter of the next).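

The swap of cyclopropyl in place of cycloheptyl on an amide-type nitrogen gives the only step shown at this position in this assay, a number 2 percentage points higher from compound 1 to compound 3 (within the scatter). The seven-membered and three-membered carbon rings therefore cannot be told apart at this place in this single-dose read-out, so this wide difference in ring size has no resolved effect on the number, and the hydroxycyclohexyl group on the same nitrogen is held constant throughout the pair. Nothing measured here speaks to the reason for this result.

On these data alone, it remains open whether any group at this place can move this assay beyond the scatter, for example an amine or a carboxylic acid carried on the cyclopropyl ring, or a longer chain in place of the ring. As far as these compounds go, it is also open whether the hydroxycyclohexyl group on the same nitrogen, or the propyl-type link to the shared core, has a larger bearing on the read-out than the ring exchanged in this step.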